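The compounds below may be only part of what the source reports. "The series", "measured", "known", "first", "only" and "open" are said of these compounds alone.

Measured in a functional assay on EBC-1 cells (Homo sapiens) for antiproliferative activity, read by sulforhodamine B assay, with a stated time of 72 h; on this read-out higher numbers stand for weaker inhibition and lower numbers for stronger inhibition:

compound 1 `Cn1cc(-c2ccc(=O)n(CCOc3ccnc4cc(OCCCC(=O)NO)ccc34)n2)cn1` gives 870 nM
compound 2 `Cn1cc(-c2ccc(=O)n(CCOc3ccnc4cc(OCCCCCC(=O)Nc5ccccc5N)ccc34)n2)cn1` gives 370 nM
compound 3 `CC(=O)CCCCCOc1ccc2c(OCCn3nc(-c4cnn(C)c4)ccc3=O)ccnc2c1` gives 25 nM

Compound 3 has the lowest number of the three, well clear of the other two. The next compound, compound 4 `CNC(=O)CCCCCOc1ccc2c(OCCn3nc(-c4cnn(C)c4)ccc3=O)ccnc2c1`, has not yet been measured in this assay. It differs from compound 3 by one small edit: methylamino in place of methyl on a carbonyl carbon, (methylamino in place of methyl on a carbonyl carbon).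

The most relevant measured change sits at that same carbonyl carbon. Methyl in place of (2-aminophenyl)amino gave a 15-fold lower number from compound 2 to compound 3 (1.17 log units; beyond the scatter). Compound 4 also carries a nitrogen on this carbon, so it may give back part of that gain. However, its methylamino group has not been tested in any measured compound, so this comparison is only a rough guide. The other two steps, a 2.4-fold lower number from compound 1 to compound 2 (0.37 log units; beyond the scatter) and a 35-fold lower number from compound 1 to compound 3 (1.54 log units; beyond the scatter), involve the hydroxycarbamoyl end group and say less about this edit.

A moderate rise in the number is therefore expected, much smaller than the gap between compound 2 and compound 3. The expected step is a 2.4-fold higher number from compound 3 to compound 4 (0.38 log units; beyond the scatter). For compound 4 the estimated value is 60 nM, with an expected range from 18 nM to 220 nM.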

Compound 4, half-maximal inhibitory concentration: 79 nM
Compound 4: the middle estimate sits 1.3-fold (0.12 log units) below what was measured; low and high end bracket the measured number.
By their numbers in this assay, from the lowest: compound 3; then compound 4; then compound 2; then compound 1.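

Placing methylamino in place of methyl on the carbonyl carbon in this assay gives a 3.2-fold higher number from compound 3 to compound 4 (0.50 log units; beyond the scatter), so a nitrogen on this carbon carries a cost, but a modest one. Until now the only nitrogen tested on this carbon bore a 2-aminophenyl group, and swapping that group for methyl on the amide-type nitrogen gives a 4.7-fold lower number from compound 2 to compound 4 (0.67 log units; beyond the scatter), so much of the earlier gap between compound 2 and compound 3 goes with the 2-aminophenyl group and not with the nitrogen alone. The methylamino end also holds up well against the hydroxycarbamoyl end, with an 11-fold lower number from compound 1 to compound 4 (1.04 log units; beyond the scatter) as the change.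

The compounds shown leave open whether the hydrogen on the amide nitrogen matters, which a dimethylamino group on this carbonyl carbon would test. They also leave open how a plain amino group or a carboxylic acid at this end would compare with methyl and methylamino. The data shown contain no evidence on what lies behind these differences.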